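This account rests on a few compounds, and the source may have more. Where it says the series, first, only, none or still open, it means among the compounds named here.

Compound 1 `CC#C[C@@H](Cc1nnn[nH]1)c1ccc(OCc2ccc3scc(-c4cncnc4C)c3c2)cc1` gives 18 nM in a functional assay on cells for agonist activity at Free fatty acid receptor 1 (Rattus norvegicus), read by FLIPR and calcium flux; a higher number here means that more compound is needed for the effect, a lower number that less compound is needed. Compound 2 `CC#C[C@@H](Cc1nnn[nH]1)c1ccc(OCc2ccc3sc(C#N)c(-c4ccccc4C)c3c2)cc1` gives 19 nM there. Compound 3 `CC#C[C@@H](Cc1nnn[nH]1)c1ccc(OCc2ccc3sc(Cl)c(-c4ccccc4C)c3c2)cc1` gives 20 nM.

Compound 3 holds the highest of the three numbers, but its distance from compound 1 and from compound 2 lies within the scatter, so the three are indistinguishable. Compound 4 `CC#C[C@@H](Cc1nnn[nH]1)c1ccc(OCc2ccc3sc(I)c(-c4ccccc4C)c3c2)cc1` differs from compound 3 by iodo in place of chloro on an aromatic carbon. For the measured compounds named here, the only measured step at this position is a 1.1-fold higher number from compound 2 to compound 3 (0.02 log units; within the scatter), a swap of one halogen-sized group for another at the same carbon that left the number unchanged. On that basis a further halogen swap is expected to give no step beyond the scatter, no change at the digits printed from compound 3 to compound 4 (within the scatter). Compound 4 is therefore estimated at 20 nM, with a range from 8 nM to 50 nM.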

Compound 4, half-maximal effective concentration: 33 nM
Compound 4: the middle estimate sits 1.7-fold (0.22 log units) below what was measured; the range from low to high includes it.
By their numbers in this assay, from the lowest: compounds 1, 2, 3 and 4 (each within the scatter of the next).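

Iodo joins cyano and chloro on the aromatic carbon next to the ring sulfur with no step beyond the scatter: this assay shows a 1.7-fold higher number from compound 3 to compound 4 (0.22 log units; within the scatter) and also a 1.7-fold higher number from compound 2 to compound 4 (0.24 log units; within the scatter) for the same swap site. These are the largest steps yet seen at this carbon, but they still do not separate the three groups. Nothing available explains these numbers. The compounds shown leave open whether an amine, a carboxylic acid or a methoxy group on this carbon would also stay within the scatter, and whether plain hydrogen there would, with the 2-methylphenyl group kept.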